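Orexin Receptor Agonism: Exchanging the Terminal Aryl Amide

This account rests on a few compounds, and the source may have more. Where it says the series, first, only, none or still open, it means among the compounds named here.

Three compounds share one core, and the account begins with compound 1 `COc1ccccc1C(=O)NCCNc1cccc(NS(=O)(=O)c2cc(-c3cccc(C(=O)N(C)C)c3)ccc2OC)c1`, which in a functional assay on CHO-K1 cells for agonist activity at Orexin/Hypocretin receptor type 1 (Homo sapiens), read by calcium flux (a lower number here means a smaller maximal response, a higher number a larger maximal response), gives 46%. Among the measured compounds shown here, compound 2 `COc1ccc(-c2cccc(C(=O)N(C)C)c2)cc1S(=O)(=O)Nc1cccc(NCCNC(=O)c2ccccc2)c1` and compound 3 `COc1ccc(-c2cccc(C(=O)N(C)C)c2)cc1S(=O)(=O)Nc1cccc(NCCNC(=O)c2ccccc2C)c1` belong to the same family, but for neither of them was a result reported in this assay: compound 2 is entered there as "not determined" (no result reported), and compound 3 is entered as "not determined" (no result reported), so compound 3 stands without a number, compound 2 does likewise, and no step between measured compounds can be drawn from these three.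

The move from compound 3 to compound 4 `COc1ccc(-c2cccc(C(=O)N(C)C)c2)cc1S(=O)(=O)Nc1cccc(NCCNC(=O)c2cccc(Cl)c2)c1` alters only the aryl group on the carbonyl carbon: 3-chlorophenyl in place of 2-methylphenyl on a carbonyl carbon. Since compound 3 has no value in this assay, the size and direction of this step cannot be judged from the data, and any expectation for compound 4 rests on compound 1 alone, whose reading of 46% is the sole anchor for the series. On that basis compound 4 is expected to reach 42% in this assay, with a range estimated from 15% to 70%.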

Compound 4, largest response reached (Emax), in percent of the reference or control that the assay uses: 73%
The estimate for compound 4 lay 31 percentage points below the measured number; measured number above the stated range.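

Compound 4 gives the series its first readable comparison at the aryl group on the carbonyl carbon: in this assay, 3-chlorophenyl in place of 2-methoxyphenyl gives a number 27 percentage points higher from compound 1 to compound 4 (beyond the scatter). The aryl group at this position can therefore shift the maximal response while the rest of the structure stays the same, although the steps involving compound 2 and compound 3 cannot be read. Nothing reported here bears on the reason for this rise.

Going by these compounds, it remains open whether the chlorine or its place on the ring matters more, as 2-methoxyphenyl and 3-chlorophenyl differ in both. Also open, on these data alone, is how a carboxylic acid or an amine on this aryl group would read in this assay.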